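This account rests on a few compounds, and the source may have more. Where it says the series, first, only, none or still open, it means among the compounds named here.

Measured compounds:
compound 1 `CC1c2ncn(Cc3ccccc3)c2NC(=O)N1Cc1ccccc1`: 98% in a functional assay on K562 cells (Homo sapiens) for cytotoxicity, read by thymidine incorporation, with a stated time of 48 h, tested at 10 ug/mL; a higher number here means more inhibition at the concentration tested (going by the name of the read-out), a lower number less inhibition
compound 2 `CC(C)C1c2ncn(Cc3ccccc3)c2NC(=O)N1Cc1ccccc1`: 51%
compound 3 `O=c1nc2c(ncn2Cc2ccccc2)c(C#Cc2ccccc2)n1Cc1ccccc1`: 100%

Compound 3 and compound 1 lie within the scatter of each other; compound 2 lies beyond the scatter below both. Compound 4 `O=c1nc2c(ncn2Cc2ccccc2)c(-c2ccccc2)n1Cc1ccccc1` is not yet measured. Against compound 3 it shows (phenyl in place of 2-phenylethynyl on an aromatic carbon). Among the compounds with values here, the one measured step, a number 47 percentage points lower from compound 1 to compound 2 (beyond the scatter), concerns a group on a saturated ring carbon, not the aromatic carbon changed here, so no measured step bears directly on this change. Compound 3 and compound 1 both give high numbers in this assay, which leaves little room upward. Compound 4 is expected to give a high number in this assay, with an estimated step of a number 15 percentage points lower from compound 3 to compound 4 (beyond the scatter) that allows for some loss. The estimate for compound 4 is 85%, from 45% to 100%.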

Compound 4, a percentage reported as inhibition, at one concentration (the size of the read-out at that concentration, not a potency): 70%
Beside the measured number, compound 4's estimate is 15 percentage points above it, within the range that was stated.
By their numbers in this assay, from the lowest: compound 2; then compound 4; then compounds 1 and 3 (each within the scatter of the next).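

In this assay, phenyl in place of 2-phenylethynyl on the aromatic carbon gives a number 30 percentage points lower from compound 3 to compound 4 (beyond the scatter), so the read-out responds to the group at this position. Both groups carry one six-membered aromatic ring of carbon only, and the triple bond is present only in the group that leaves. No available evidence accounts for this step.

Still open, going by these compounds, is whether the triple bond itself matters, which a 2-phenylethyl group at this carbon would address. An amine here would show whether an aromatic ring is needed at all.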